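The source may report more compounds than this note shows. Statements on the series, on what has been measured and on what is new or still open speak of the compounds shown alone.

Of the compounds shown here, three built on the same core have been tested in a functional assay on C6 cells (Rattus norvegicus) for cytotoxicity, read by MTT assay, with a stated time of 24 h, tested at 6 ug/mL; on this read-out lower numbers stand for a stronger effect and higher numbers for a weaker effect at the one concentration tested. Compound 1 `O=C(CSc1ncccn1)N/N=c1/scc(-c2ccc(F)cc2)n1-c1ccccc1` gives 84%. Compound 2 `COc1ccc(-c2cs/c(=N/NC(=O)CSc3ncccn3)n2-c2ccccc2)cc1` gives 89.6%, and compound 3 `Cc1ccc(-c2cs/c(=N/NC(=O)CSc3ncccn3)n2-c2ccccc2)cc1` gives 93.2%. The steps between them, a number 5.6 percentage points higher from compound 1 to compound 2 (within the scatter), a number 9.2 percentage points higher from compound 1 to compound 3 (within the scatter) and a number 3.6 percentage points higher from compound 2 to compound 3 (within the scatter), all change a group on an aromatic carbon, and all stay within the scatter. Compound 3 thus shows the highest of the three numbers, yet with both gaps inside the scatter it cannot be set apart from compound 1 or compound 2.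

Compound 4 `Cc1ccc(-c2cs/c(=N/NC(=O)CSc3nnnn3C)n2-c2ccccc2)cc1` has not yet been measured. It differs from compound 3 in one place: 1-methyl-1H-tetrazol-5-yl in place of pyrimidin-2-yl on a sulfur. Going by the values given here, no measured step touches the group on the sulfur; the three known steps all concern the aromatic carbon, and each was within the scatter. Among the compounds with values here, the only guide is that every change tried so far has left the number close to where it was. Compound 4 is expected to give 90%, between 72% and 100%. The expected step of a number 3.2 percentage points lower from compound 3 to compound 4 (within the scatter) is not thought to reach beyond the scatter, and the range is set wide, as nothing measured speaks to this part of the molecule.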

Compound 4, a percentage reported as activity, at one concentration (the size of the read-out at that concentration, not a potency): 88%
Estimate against measurement, compound 4: 2 percentage points above; measured number inside the range.
By their numbers in this assay, from the lowest: compounds 1, 4, 2 and 3 (each within the scatter of the next).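

In this assay, going by these compounds alone, putting 1-methyl-1H-tetrazol-5-yl in place of pyrimidin-2-yl on the sulfur gives a number 5.2 percentage points lower from compound 3 to compound 4 (within the scatter), the first reading for this part of the molecule. The group on the sulfur can therefore go from a six-membered aromatic ring with 2 hetero atoms to a five-membered aromatic ring with 4 hetero atoms without a shift that can be told from the usual scatter. Nothing available speaks to the reason for this result.

Going by these compounds, it stays open whether a group of another kind on the sulfur, such as an open alkyl chain, an amine or a carboxylic acid, would move the number beyond the scatter. On these data alone, it is also open whether 1-methyl-1H-tetrazol-5-yl behaves the same way when the methyl on the aromatic carbon is replaced by fluoro or methoxy.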